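A few compounds are considered here, and "the series" means these few. Any claim that something is new, unique, unknown or untested is made for them only; others in the source may bear on it.

Within the data shown here, in a functional assay on HepG2 cells (Homo sapiens) for cytotoxicity, read by MTT assay, with a stated time of 48 h (on this read-out higher numbers stand for weaker inhibition and lower numbers for stronger inhibition), only two compounds have numbers so far. Compound 1 (`O=C(CSCc1nc2cc([N+](=O)[O-])ccc2[nH]1)c1ccc(Cl)cc1`) gives 2650 nM and stands lowest of the two, while compound 2 (`N#Cc1sc(Nc2ccccc2)nc1NC(=O)CSCc1nc2cc([N+](=O)[O-])ccc2[nH]1`) gives 9480 nM and lies beyond the usual scatter from it. Compound 3 (`CC1=NN(C(=O)CSCc2nc3cc([N+](=O)[O-])ccc3[nH]2)C(=O)C1`) awaits measurement. It departs from compound 1 in one place (a group of 7 heavy atoms (4 carbon, 2 nitrogen, 1 oxygen; one five-membered non-aromatic ring with 2 hetero atoms) in place of a group of 7 heavy atoms (6 carbon, 1 chlorine; one six-membered aromatic ring of carbon only), on a carbonyl carbon), on a carbonyl carbon. Among the measured compounds shown here, no step between measured compounds shows such a swap, so the expectation is loose. Compound 2 at 9480 nM also lacks the 4-chlorophenyl, and on that single comparison a moderate rise in the number in this assay is expected, beyond the scatter but not large. The estimated change is a 2.3-fold higher number from compound 1 to compound 3 (0.35 log units; beyond the scatter) in all. For compound 3 the expected value is 6000 nM with a range from 2000 nM to 18000 nM as its likely span.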

Compound 3, half-maximal inhibitory concentration: 7330 nM
Compound 3: the middle estimate sits 1.2-fold (0.09 log units) below what was measured, and the stated range covers the measured number.
By their numbers in this assay, from the lowest: compound 1; then compounds 3 and 2 (each within the scatter of the next).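

Among these compounds, the step gives the first direct reading at this place, on a carbonyl carbon whose other neighbours are a saturated chain carbon: in this assay, exchanging the 4-chlorophenyl for the five-membered non-aromatic ring with 2 hetero atoms gives a 2.8-fold higher number from compound 1 to compound 3 (0.44 log units; beyond the scatter). The change keeps the count of 7 heavy atoms but adds 2 hydrogen-bond acceptors, so the modest rise comes with a change in ring type and atom make-up rather than in group size. Nothing available explains the rise.

The compounds shown leave open whether the rise follows from losing the chlorine or from losing the six-membered aromatic ring, which a plain phenyl at this place would separate. On these data alone, how a piperidine or a simple methyl on the same carbonyl carbon would read also remains open.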